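The compounds below may be only part of what the source reports. "The series", "measured", "known", "first", "only" and "open" are said of these compounds alone.

Measured compounds:
Compound 1, `CCOc1cc(C2CCN(C)CC2)ccc1Nc1ncc2c(n1)N(Cc1ccc(Br)cc1)[C@H](CC)C(=O)N2C`, which in an assay on isolated protein for inhibition of serine/threonine-protein kinase PLK1 (Homo sapiens), read by Z'-LYTE, with a stated time of 60 min (on this read-out higher numbers stand for weaker inhibition and lower numbers for stronger inhibition), gives "not determined" (no result reported).
Compound 2, `CCOc1cc(C2CCN(C)CC2)ccc1Nc1ncc2c(n1)N(Cc1sccc1C)[C@H](CC)C(=O)N2C`, which in this assay gives 68 nM.

For the measured compounds named here, compound 2 therefore carries the only number in this assay here; compound 1 has no single value, so nothing can be said about how the two stand against each other. Compound 3, `CCOc1cc(C2CCN(C)CC2)ccc1Nc1ncc2c(n1)N(Cc1cccc(Cl)c1)[C@H](CC)C(=O)N2C`, is still to be measured in this assay. It differs from compound 2 in one place: 3-chlorophenyl in place of 3-methylthiophen-2-yl on a saturated chain carbon bound to a nitrogen on an aromatic ring in a ring. A five-membered aromatic ring with one hetero atom, the 3-methylthiophen-2-yl group, gives way to a six-membered ring of carbon only carrying a chlorine, the 3-chlorophenyl group, on a saturated chain carbon bound to a nitrogen on an aromatic ring in a ring. Going by the values given here, no pair of measured compounds shows what such a swap does in this assay, so the size of the step cannot be read from the data. A small step is expected, within the scatter or a little toward weaker inhibition: a 1.3-fold higher number from compound 2 to compound 3 (0.12 log units; within the scatter). For compound 3 the estimate is 90 nM, with a likely range from 30 nM to 300 nM.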

Compound 3, half-maximal inhibitory concentration: 540 nM
Compound 3: the middle estimate sits 6.0-fold (0.78 log units) below what was measured, outside the stated range (above it).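

In this assay, replacing the (3-methylthiophen-2-yl)methyl group with 3-chlorobenzyl gives a 7.9-fold higher number from compound 2 to compound 3 (0.90 log units; beyond the scatter), so inhibition is weaker by more than the usual scatter. For the compounds shown here, this is the first readable pair, and it shows that the group on this saturated chain carbon, bound to a nitrogen on an aromatic ring in a ring, can change the result even when the rest of the molecule stays the same and the group grows by only one heavy atom. The data shown include no measurement that accounts for this loss, so its cause remains unknown.

This single step changes several things at once: the ring size, the sulfur in the ring, and a methyl group replaced by a chlorine, so it cannot say which of them matters, and compound 1, at "not determined" (no result reported), adds no comparison. A plain phenyl ring or an unsubstituted thiophene on the same carbon would help pull these changes apart, and a pyridine ring would show how a ring nitrogen fares at this place.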